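Removing One Methoxy Group from Two Related Cytotoxic Compounds

The source may report more compounds than this note shows. Statements on the series, on what has been measured and on what is new or still open speak of the compounds shown alone.

Measured compounds:
compound 1, `COc1cc(-c2cc(/C=C/C(=O)c3ccc(N)cc3)[nH]n2)cc(OC)c1OC`, gives -22%
compound 2, `COc1ccc(-c2cc(/C=C/C(=O)c3ccc(N)cc3)[nH]n2)cc1OC`, gives 24%
compound 3, `COc1cc(C(=O)/C=C/c2cc(-c3cc(OC)c(OC)c(OC)c3)n[nH]2)cc(OC)c1OC`, gives -100%

All three numbers come from a functional assay on OVCAR-4 cells (Homo sapiens) for cytotoxicity, read by sulforhodamine B assay, with a stated time of 48 h, tested at 10 uM; on this read-out lower numbers stand for a stronger effect and higher numbers for a weaker effect at the one concentration tested. Compound 1 and compound 2 differ in one place, (hydrogen in place of methoxy on an aromatic carbon), and this change produced a step of a number 46 percentage points higher from compound 1 to compound 2 (beyond the scatter). Compound 3 stands lowest of the three; the difference between the core of compound 3 and the core of compound 1 is not broken down here. Compound 4, `COc1ccc(-c2cc(/C=C/C(=O)c3cc(OC)c(OC)c(OC)c3)[nH]n2)cc1OC`, has not yet been measured in this assay. It differs from compound 3 by hydrogen in place of methoxy on an aromatic carbon, the same change that separates compound 1 from compound 2. The step from compound 3 to compound 4 in this assay is expected to be a number 50 percentage points higher from compound 3 to compound 4 (beyond the scatter), and this expectation rests on the earlier step because a number 46 percentage points higher from compound 1 to compound 2 (beyond the scatter) was seen for the same change. Compound 4 is therefore estimated to give -50%, with a range from -100% to 10%.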

Compound 4, a percentage reported as activity, at one concentration (the size of the read-out at that concentration, not a potency): -11%
Compound 4: the middle estimate sits 39 percentage points below what was measured; the range from low to high includes it.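

Removing the methoxy group gave a weaker effect in this assay on both cores, so the direction of the change held on the core of compound 3, with a number 89 percentage points higher from compound 3 to compound 4 (beyond the scatter). The size of the step did not carry over from one core to the other: the same change on two cores in this assay, a number 46 percentage points higher (beyond the scatter) from compound 1 to compound 2 and a number 89 percentage points higher (beyond the scatter) from compound 3 to compound 4, 43 percentage points apart, beyond the scatter of two such steps These two pairs show a shared direction, but they give no rule for the size of the step on a further core and do not explain why the two steps differ.

The compounds shown leave open what a hydroxyl group, an ethoxy group or a fluorine atom would do in the place of this methoxy group. They also leave open whether either step would hold in other cells.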